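The source may hold more compounds than are shown below. What is called first, only, known or untested is meant among the compounds shown, and "the series" means these compounds.

Measured compounds:
- compound 1, `CCCNS(=O)(=O)c1ccc(Nc2ncc3c(n2)N(C2CCCC2)[C@H](CC)C(=O)N3C)cc1`: 344 nM
- compound 2, `CC[C@@H]1C(=O)N(C)c2cnc(-n3ccc4cc(F)ccc43)nc2N1C1CCCC1`: "not active" (no number reported)
- compound 3, `CCC1C(=O)N(C)c2cnc(-n3ccc4cc(C(N)=O)ccc43)nc2N1c1ccn(C)n1`: "not active" (no number reported)

Among the compounds with values here, in a functional assay on MCF7 cells (Homo sapiens) for antiproliferative activity, read by CCK-8 assay, with a stated time of 72 h (a higher number here means a weaker inhibitor of growth, a lower number a stronger inhibitor of growth), compound 1 is the only compound with a number. Compound 2 is reported without one, as "not active" (no number reported); compound 3 is likewise reported without one, as "not active" (no number reported). Compound 4, `CC[C@@H]1C(=O)N(C)c2cnc(Nc3ccc(S(=O)(=O)NC4CCCC4)cc3)nc2N1C1CCCC1`, has not yet been measured in this assay. It differs from compound 1 in one place: cyclopentyl in place of propyl on a sulfonamide nitrogen, which reads, one bond further out, as propylsulfamoyl to cyclopentylsulfamoyl. Within the data shown here, no step between measured compounds is available to size this change. The five-carbon ring in place of the three-carbon chain is expected to leave the potency close to that of compound 1, with the step of a 1.4-fold lower number from compound 1 to compound 4 (0.14 log units; within the scatter) estimated to lie within the scatter or slightly in the stronger direction. Compound 4 is therefore expected to give about 250 nM, between 100 nM and 700 nM.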

Compound 4, concentration for 50% growth inhibition: 688 nM
Estimate against measurement, compound 4: 2.8-fold (0.44 log units) below; the range from low to high includes it.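

In this assay, within the data shown here, cyclopentyl in place of propyl on a sulfonamide nitrogen gives a 2.0-fold higher number from compound 1 to compound 4 (0.30 log units; within the scatter), the first step that can be read at this position. A five-membered carbon ring thus holds the growth-inhibitory potency of compound 1 within the usual scatter, so this exchange does not separate the two compounds. Nothing available explains this result. On these data alone, whether the position accepts a longer chain, a phenyl ring or a chain ending in an amine stays open. So does the outcome with only hydrogen on that sulfonamide nitrogen.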